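A few compounds are considered here, and "the series" means these few. Any claim that something is new, unique, unknown or untested is made for them only; others in the source may bear on it.

Compound 1 `NC(=O)c1c(NC(=O)c2ccccc2Cl)sc2c1CCN(C(=S)Nc1ccccc1Br)C2` gives 10800 nM in a functional assay on MKN-74 cells (Homo sapiens) for antiproliferative activity, with a stated time of 24 h; on this read-out lower numbers stand for stronger inhibition and higher numbers for weaker inhibition. Compound 2 `NC(=O)c1c(NC(=O)c2ccccc2Cl)sc2c1CCN(C(=S)Nc1ccccc1I)C2` gives 2630 nM in this assay, and the step of a 4.1-fold lower number from compound 1 to compound 2 (0.61 log units; beyond the scatter) goes with a single change, (iodo in place of bromo on an aromatic carbon). Compound 3 `NC(=O)c1c(NC(=O)c2ccccc2Br)sc2c1CCN(C(=S)Nc1ccccc1Cl)C2` gives 12900 nM in this assay; it holds the same atoms as compound 1 joined differently, and the difference between the two cores is not broken down here. The values of compound 3 and compound 1 lie within the scatter of each other, so nothing separates them.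

Compound 4 `NC(=O)c1c(NC(=O)c2ccccc2I)sc2c1CCN(C(=S)Nc1ccccc1Cl)C2` is not yet measured. It differs from compound 3 by iodo in place of bromo on an aromatic carbon. The place reads the same as for the earlier change, on an aromatic carbon of a six-membered aromatic ring of carbon only, ortho to a large group; cut one bond further out, the earlier change reads (2-bromophenyl)amino to (2-iodophenyl)amino, whereas this one reads (2-bromophenyl)carbonyl to (2-iodophenyl)carbonyl, so the ring carrying the halogen is not the same one.

For compound 4 the expected step is a 2.3-fold lower number from compound 3 to compound 4 (0.37 log units; beyond the scatter). Among the compounds with values here, that expectation rests on the single precedent a 4.1-fold lower number from compound 1 to compound 2 (0.61 log units; beyond the scatter); with the halogen on the other ring, a full repeat is uncertain. Compound 4 is therefore estimated at 5500 nM, within a range from 2200 nM to 14000 nM.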

Compound 4, half-maximal inhibitory concentration: 17500 nM
Beside the measured number, compound 4's estimate is 3.2-fold (0.50 log units) below it, outside the stated range (above it).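

In this assay, iodo in place of bromo on the ring of the (2-bromophenyl)carbonyl group gives a 1.4-fold higher number from compound 3 to compound 4 (0.13 log units; within the scatter), so on this core the change does not separate the two compounds. The change therefore does not carry over as a fixed increment between these two cores: the same change on two cores in this assay, a 4.1-fold lower number (0.61 log units; beyond the scatter) from compound 1 to compound 2 and a 1.4-fold higher number (0.13 log units; within the scatter) from compound 3 to compound 4, 5.6-fold (0.75 log units) apart, beyond the scatter of two such steps. What this does not show is the source of the gap: the two pairs differ both in which ring carries the changing halogen and in the arrangement of the other halogen, and two pairs cannot separate these or predict the step on any further core.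

As far as these compounds go, all four compounds carry a halogen on both aromatic rings, so it remains open how a methoxy group, an amine or a carboxylic acid in place of either halogen would read. Also open, from the compounds shown here alone, is whether the step would look different in a compound with iodo on both rings.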